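Trimming the Aryl Substituent in an Antiproliferative Series

The source may report more compounds than this note shows. Statements on the series, on what has been measured and on what is new or still open speak of the compounds shown alone.

Compound 1, `Cc1nn(-c2nc(-c3ccc(Cl)c(Cl)c3)c(SC(C)C)s2)c(C(=O)O)c1Cc1ccccc1[N+](=O)[O-]`: 20000 nM
Compound 2, `Cc1cc(Cl)cc(-c2c(C)nn(-c3nc(-c4ccc(Cl)c(Cl)c4)c(SC(C)C)s3)c2C(=O)O)c1`: 663 nM
Compound 3, `COc1cc(Cl)cc(-c2c(C)nn(-c3nc(-c4ccc(Cl)c(Cl)c4)c(SC(C)C)s3)c2C(=O)O)c1`: 760 nM

In a functional assay on BJAB cells (Homo sapiens) for antiproliferative activity, with a stated time of 4 days (on this read-out lower numbers stand for an effect already at smaller amounts and higher numbers for an effect only at larger amounts of compound), compound 3 stands second highest of the three numbers. Its nearest neighbour is compound 2, since a 1.1-fold higher number from compound 2 to compound 3 (0.06 log units; within the scatter) sits within the scatter, while compound 1 is furthest away, with a 26-fold lower number from compound 1 to compound 3 (1.42 log units; beyond the scatter) well beyond it. Compound 4, `Cc1cccc(-c2c(C)nn(-c3nc(-c4ccc(Cl)c(Cl)c4)c(SC(C)C)s3)c2C(=O)O)c1`, is not yet measured; its change from compound 3 is 3-methylphenyl in place of 3-chloro-5-methoxyphenyl on an aromatic carbon. Going by the values given here, only one measured step bears directly on this change: a 1.1-fold higher number from compound 2 to compound 3 (0.06 log units; within the scatter), which shows methoxy and methyl exchanging without a shift beyond the scatter. Among the compounds with values here, no measured pair covers the loss of the chlorine, so that part is untested. Compound 4 is therefore expected to show a 1.3-fold higher number from compound 3 to compound 4 (0.12 log units; within the scatter), a step not beyond the scatter, with an estimate of 1000 nM (range 400 nM to 2500 nM).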

Compound 4, half-maximal effective concentration: 17000 nM
The estimate for compound 4 lay 17-fold (1.23 log units) below the measured number, and the stated range ends below it.
By their numbers in this assay, from the lowest: compounds 2 and 3 (each within the scatter of the next); then compounds 4 and 1 (each within the scatter of the next).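

In this assay the chlorine of the aryl group proves decisive: hydrogen in place of chloro alone gives a 26-fold higher number from compound 2 to compound 4 (1.41 log units; beyond the scatter) and the full change gives a 22-fold higher number from compound 3 to compound 4 (1.35 log units; beyond the scatter) at this position. Going by these compounds alone, the earlier exchange of methoxy and methyl within the scatter was seen only with the chlorine present. Without it, 3-methylphenyl stands with 2-nitrobenzyl, at a 1.2-fold lower number from compound 1 to compound 4 (0.07 log units; within the scatter) and within the scatter.

Open, as far as these compounds go, is whether fluoro, bromo or an amine at that aryl carbon could replace the chlorine, and whether methoxy without chlorine behaves like methyl. Nothing available explains the loss.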